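Working notes: cytotoxicity series, compounds 1 to 4

A few compounds are considered here, and "the series" means these few. Any claim that something is new, unique, unknown or untested is made for them only; others in the source may bear on it.

Measured compounds:
compound 1, `O=[N+]([O-])c1cc(-c2nnn(Cc3ccccc3)n2)cc([N+](=O)[O-])c1`: 150000 nM
compound 2, `O=[N+]([O-])c1cc(-c2nnn(Cc3ccc(Cl)cc3)n2)cc([N+](=O)[O-])c1`: 170000 nM
compound 3, `O=[N+]([O-])c1cc(-c2nnn(Cc3cccc(Br)c3)n2)cc([N+](=O)[O-])c1`: 29000 nM

All three were read in an ADME assay on CHO-K1 cells (Cricetulus griseus) for cytotoxicity, read by MTT assay, with a stated time of 24 h; a lower number here means a stronger inhibitor, a higher number a weaker inhibitor. Compound 1 gives 150000 nM, the second highest of the three numbers. The step of a 1.1-fold higher number from compound 1 to compound 2 (0.05 log units; within the scatter) lies within the scatter, whereas the step of a 5.2-fold lower number from compound 1 to compound 3 (0.71 log units; beyond the scatter) is the only one beyond it.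

Compound 4, `O=[N+]([O-])c1cc(-c2nnn(Cc3ccccc3F)n2)cc([N+](=O)[O-])c1`, is the next member of the series; it differs from compound 1 by fluoro in place of hydrogen on an aromatic carbon. Among the compounds with values here, two measured steps bear on this change, since both replace a hydrogen on the same six-membered ring with a halogen: a 1.1-fold higher number from compound 1 to compound 2 (0.05 log units; within the scatter) and a 5.2-fold lower number from compound 1 to compound 3 (0.71 log units; beyond the scatter). They disagree with each other, and neither places its halogen where the fluoro of compound 4 sits, so they give no firm direction. The expectation is therefore a small step, at most modest and plausibly within the scatter. Compound 4 is expected to give 120000 nM in this assay, with a range of 50000 nM to 250000 nM. This estimate amounts to a 1.3-fold lower number from compound 1 to compound 4 (0.10 log units; within the scatter).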

Compound 4, half-maximal inhibitory concentration: > 200000 nM
Compound 4: a limit, no number (the forecaster's own chance of this, stated with the estimate: 5%); middle value at least 1.6-fold (0.22 log units) from the limit.
By their numbers in this assay, from the lowest: compound 3; then compounds 1 and 2 (each within the scatter of the next). At a limit, above all of these: compound 4.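

In this assay compound 4 is read only as a limit, not as a number: the limit of > 200000 nM in this assay, at which 1 of the 4 values shown sits. Fluoro on an aromatic carbon, ortho to a large group, does not bring the lower number seen with the bromo of compound 3, as shown by an at least 6.8-fold higher number from compound 3 to compound 4 (0.83 log units; beyond the scatter). Going by these compounds, the floors of the other two steps say little on their own, an at least 1.3-fold higher number from compound 1 to compound 4 (0.12 log units; that floor lies within the scatter) and an at least 1.1-fold higher number from compound 2 to compound 4 (0.07 log units; that floor lies within the scatter), so the true size of both stays unknown.

The compounds shown leave open whether the lower number of compound 3 belongs to bromo itself or to its place on the ring, since compound 3 is the only one of the four that departs from the rest. On these data alone, how an amine or a carboxylic acid at the position of the fluoro would read is also open.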